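The source may report more compounds than this note shows. Statements on the series, on what has been measured and on what is new or still open speak of the compounds shown alone.

Measured so far:
compound 1, `N=C(N)Nc1cccc(C(=O)NNC(=O)CC(CC(=O)O)c2ccc(-c3ccccc3)cc2)c1`, with 2.8 in a physicochemical assay for lipophilicity; a lower number here means a more polar compound, a higher number a more lipophilic compound;
compound 2, `CC(=N)Nc1cccc(C(=O)NNC(=O)CC(CC(=O)O)c2ccc(Cl)cc2)c1`, with 2 in this assay.

Of the two measured compounds, compound 2 stands lowest in this assay; its nearest neighbour is compound 1, which lies higher by a gap beyond the usual scatter. Compound 1 and compound 2 differ in more than one place, so the gap between them is not tied to a single change; the two values alone are what they show.

The unmeasured compound 3, `CC(=N)Nc1cccc(C(=O)NNC(=O)CC(CC(=O)O)c2ccc(-c3ccccc3)cc2)c1`, departs from compound 2 in one place: phenyl in place of chloro on an aromatic carbon, para to a large group. Within the data shown here, no measured pair isolates this exchange, so the size of the step rests on expectation. Because compound 1 with its own phenyl gives 2.8, a move upward beyond the scatter is expected. The step of a number 1.10 log units higher from compound 2 to compound 3 (beyond the scatter) is the expected change. Compound 3 is therefore estimated at 3.1, with a range from 2.5 to 3.7.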

Compound 3, partition coefficient: 3.11
Beside the measured number, compound 3's estimate is 0.01 log units below it; measured number inside the range.
By their numbers in this assay, from the lowest: compound 2; then compound 1; then compound 3.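

Among these compounds, with compound 3, the exchange of chloro for phenyl on an aromatic carbon, para to a large group, can be read on its own for the first time: in this assay it gives a number 1.11 log units higher from compound 2 to compound 3 (beyond the scatter), a large step beyond the scatter. The same compound also isolates a second place, the carbon with a double bond to nitrogen, where methyl in place of amino gives a number 0.31 log units higher from compound 1 to compound 3 (beyond the scatter), a modest step that still lies beyond the scatter, so the earlier gap between compound 1 and compound 2 can now be seen as the sum of changes at two places. Nothing measured here accounts for either step.

The compounds shown leave open whether a methoxy group, a cyclohexyl ring or a single methyl at this aromatic carbon would fall nearer to chloro or to phenyl in this assay. They also leave open whether the exchange of chloro for phenyl would give a step of the same size with amino rather than methyl on the carbon with a double bond to nitrogen, and how an ester in place of the carboxylic acid would read.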